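The compounds below may be only part of what the source reports. "The series", "measured", "known", "first", "only" and "open" are said of these compounds alone.

Working notes on the series in an ADME assay on L929 cells (Mus musculus) for cytotoxicity, read by resazurin assay, with a stated time of 96 h; a lower number here means that less compound is tolerated, a higher number that more compound is tolerated. Among the compounds with values here, compound 2 `NC(=S)N/N=C(\COc1ccccc1)c1ccc(Br)cc1` gives 54900 nM, the only actual number available so far. Compound 1 `NC(=S)N/N=C(/COc1ccc(Br)cc1)c1ccc(F)cc1` gives only a limit, < 26200 nM. Within the data shown here, the position of compound 2 in the series therefore cannot yet be fixed against a second number, and no single-change step between measured compounds is available to calibrate the size of a change.

The next compound is compound 3 `CCc1ccc(OC/C(=N\NC(N)=S)c2ccc(Br)cc2)cc1`. Its difference from compound 2 is ethyl in place of hydrogen on an aromatic carbon, para to a large group.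

A small shift towards less tolerated compound is expected, possibly no larger than the usual scatter. This cautious lean rests on compound 1, which also carries a substituent on that aromatic ring and whose result is the limit < 26200 nM. The estimated change a 1.8-fold lower number from compound 2 to compound 3 (0.26 log units; within the scatter) is therefore modest. For compound 3 the expected value is an estimated 30000 nM, with an estimated range of 11000 nM to 70000 nM.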

Compound 3, half-maximal cytotoxic concentration: < 25500 nM
Compound 3: only a limit was reported; the forecaster's own chance of this, stated with the estimate: 25%; middle value at least 1.1-fold (0.07 log units) away from the limit.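

Ethyl in place of hydrogen on an aromatic carbon, para to a large group, gives an at least 2.1-fold lower number from compound 2 to compound 3 (0.33 log units; beyond the scatter) in this assay, and this is the first single-change step in the series. It shows that this position is not silent in this assay: adding the ethyl group moves the number beyond the scatter, towards less compound being tolerated. Compound 3 is reported only as a limit, so the step fixes a direction and a minimum size while its full size stays unknown: the limit of < 25500 nM in this assay, at which 1 of the 3 values shown sits.

On these data alone, whether a methyl group, a longer chain such as butyl, an amine or a carboxylic acid in the same place would give a step of similar size remains open, so the shift cannot yet be tied to ethyl itself rather than to any substituent at this position. Also open, as far as these compounds go, is whether the same change would give a similar step on a compound other than compound 2, and an actual number in place of a limit would be needed to size any such step fully.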